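The compounds below may be only part of what the source reports. "The series", "measured", "known", "first", "only" and "open" are said of these compounds alone.

Measured so far:
- compound 1, `CCOC(=O)c1cccc(-c2cccs2)c1`: 55%
- compound 2, `CCOc1ccc(-c2cccc(NC(=O)N(C)C)c2)cc1`: 68%
- compound 3, `CN(C)C(=O)Nc1cccc(-c2ccc(N(C)C)cc2)c1`: 98%

In an assay on COS-7 cells for inhibition of patatin-like phospholipase domain-containing protein 2 (Mus musculus), tested at 200 uM (on this read-out higher numbers stand for more inhibition at the one concentration tested (going by the name of the read-out) and lower numbers for less inhibition), compound 3 stands highest of the three measured compounds. Its nearest neighbour is compound 2, and the gap between them is beyond the scatter; compound 1 lies furthest away, also beyond the scatter.

The step now followed leads from compound 3 to compound 4, `CN(C)c1ccc(-c2cccc(NC(=O)C(C)(C)C)c2)cc1`. The change is tert-butyl in place of dimethylamino on a carbonyl carbon. It sits on the carbonyl carbon whose other neighbour is the amide-type nitrogen, so the dimethylcarbamoylamino group becomes a (tert-butyl)carbonylamino group.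

Among the compounds with values here, only one measured step is known, a number 30 percentage points higher from compound 2 to compound 3 (beyond the scatter), and it concerns the dimethylamino group on the aromatic ring, not the carbonyl side of the molecule. Within the data shown here, no measured pair shows what swapping dimethylamino for tert-butyl on the carbonyl carbon does. The expectation therefore rests on compound 3 alone, which already sits near the top of this read-out, leaving little room upward and more room downward.

Compound 4 is expected to give 70% in this assay, estimated within a range of 35% to 95%. The step of a number 28 percentage points lower from compound 3 to compound 4 (beyond the scatter) is expected, with wide uncertainty.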

Compound 4, a percentage reported as inhibition, at one concentration (the size of the read-out at that concentration, not a potency): 25%
Beside the measured number, compound 4's estimate is 45 percentage points above it; the measured number lies below the stated range.
By their numbers in this assay, from the lowest: compound 4; then compound 1; then compound 2; then compound 3.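

In this assay the group on the carbonyl carbon proves to count heavily: putting tert-butyl in place of dimethylamino gives a number 73 percentage points lower from compound 3 to compound 4 (beyond the scatter) and leaves the rest of the molecule untouched, so the whole change belongs to this one place. Within the data shown here, until now the only measured step, a number 30 percentage points higher from compound 2 to compound 3 (beyond the scatter), concerned a group on an aromatic carbon and said nothing about the carbonyl side, whereas this pair shows that the high number of compound 3 depends on both places and does not survive a change at the carbonyl carbon alone. Nothing shown here tells why the number falls so far, whether what matters is the nitrogen that leaves or the carbon-only group that enters.

Still open, from the compounds shown here alone, is how other groups on the same carbonyl carbon would read, for example a plain methyl, a methoxy group or a pyrrolidine ring, any of which would help separate the nitrogen from the size of the group. Also open, going by these compounds, is whether tert-butyl on the carbonyl carbon has a similar effect when ethoxy stands on the aromatic carbon in place of dimethylamino.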